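This account rests on a few compounds, and the source may have more. Where it says the series, first, only, none or still open, it means among the compounds named here.

Compound 1, `Oc1ccccc1-c1cc(-c2cccc(F)c2)cc(-c2ccccc2O)n1`, is the reference point of the series. In a functional assay on T47D cells (Homo sapiens) for inhibition (a lower number here means a stronger inhibitor, a higher number a weaker inhibitor), compound 1 gives > 50000 nM, which is a limit of the assay rather than a number. Compound 2, `Oc1ccccc1-c1cc(-c2cccc(C(F)(F)F)c2)cc(-c2ccccc2O)n1`, carries a trifluoromethyl in place of fluoro on an aromatic carbon. In this assay compound 2 gives > 50000 nM, again a limit. The step that the two limits leave unreadable from compound 1 to compound 2 is therefore not readable; compound 2 sits at the limit of > 50000 nM in this assay, at which 2 of the 2 values shown sit, and nothing in the numbers sets it apart from compound 1. Compound 3, `Oc1ccccc1-c1cc(-c2cccc(OC(F)(F)F)c2)cc(-c2ccccc2O)n1`, differs from compound 2 by trifluoromethoxy in place of trifluoromethyl on an aromatic carbon. Among the compounds with values here, the only measured step, from compound 1 to compound 2, bears on this change, and its size cannot be read from two limits. No step beyond the scatter is expected in this assay for compound 3 in either direction. Compound 3 is expected to give about 80000 nM, with a range from 30000 nM to 300000 nM. The estimated step that the limit leaves unreadable from compound 2 to compound 3 is expected to stay within the scatter.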

Compound 3, half-maximal inhibitory concentration: > 50000 nM
Compound 3 ended at the assay's limit; the forecaster's own chance of this, stated with the estimate: 85%; the middle value is on the limit's open side.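

No step can be read among compound 1, compound 2 and compound 3 in this assay, since each value is a limit: the limit of > 50000 nM in this assay, at which 3 of the 3 values shown sit. The compounds shown leave open whether fluoro, trifluoromethyl and trifluoromethoxy differ at all in this assay, and which change to the shared core would give a readable value.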